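This account rests on a few compounds, and the source may have more. Where it says the series, first, only, none or still open, it means among the compounds named here.

Measured so far in an assay on microsomes from brain for inhibition of Fatty-acid amide hydrolase 1 (Rattus norvegicus), read by fluorescence and HPLC, with a stated time of 60 min; a lower number here means a stronger inhibitor, a higher number a weaker inhibitor:

compound 1, `CCCCCCCCc1ccc(OCC(=O)Cn2nnc(-c3ccccc3Cl)n2)cc1`, gives 32 nM
compound 2, `CCCCCCCCc1ccc(OCC(=O)Cn2nnc(-c3ccc(S(=O)(=O)N(C)C)cc3)n2)cc1`, gives 590 nM
compound 3, `CCCCCCCCc1ccc(OCC(=O)Cn2nnnc2-c2ccccc2Cl)cc1`, gives 4600 nM

Compound 1 and compound 3 are built from the same atoms joined differently; how their two cores differ is not broken down here. Within the core of compound 1, one change has been measured: 4-(dimethylsulfamoyl)phenyl in place of 2-chlorophenyl on an aromatic carbon. This change gave an 18-fold higher number from compound 1 to compound 2 (1.27 log units; beyond the scatter), a clear weakening.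

Compound 4, `CCCCCCCCc1ccc(OCC(=O)Cn2nnnc2-c2ccc(S(=O)(=O)N(C)C)cc2)cc1`, is not yet measured. It comes from compound 3 by the same kind of change, (4-(dimethylsulfamoyl)phenyl in place of 2-chlorophenyl on an aromatic carbon). The surroundings of the place differ slightly in the two cores: in compound 1 the changed carbon is two ring bonds from the ring atom that bears a large group, whereas in compound 3 it is next to that ring atom.

Compound 3 already stands highest of the three values. If the change behaves in its core as it did from compound 1 to compound 2, compound 4 is expected to be weaker still, by about an 8.7-fold higher number from compound 3 to compound 4 (0.94 log units; beyond the scatter), because the earlier change gave an 18-fold higher number from compound 1 to compound 2 (1.27 log units; beyond the scatter). On that basis compound 4 is estimated at 40000 nM, likely between 8000 nM and 150000 nM, with a real chance that this assay reports only a limit.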

Compound 4, half-maximal inhibitory concentration: 1400 nM
Beside the measured number, compound 4's estimate is 29-fold (1.46 log units) above it, and the stated range ends above it.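

In this assay, putting 4-(dimethylsulfamoyl)phenyl in place of 2-chlorophenyl on the core of compound 3 gave a 3.3-fold lower number from compound 3 to compound 4 (0.52 log units; beyond the scatter), a modest strengthening, whereas the same change weakened inhibition on the core of compound 1. The change therefore did not carry over between these two cores, either in direction or in size: the same change on two cores in this assay, an 18-fold higher number (1.27 log units; beyond the scatter) from compound 1 to compound 2 and a 3.3-fold lower number (0.52 log units; beyond the scatter) from compound 3 to compound 4, 61-fold (1.78 log units) apart, beyond the scatter of two such steps. Going by these compounds alone, with only one pair of steps, this shows that the effect of the change on one core cannot safely be assumed for the other, but it does not show why the two cores differ or how any other group would behave.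

The compounds shown leave open whether other groups at this place, such as an amine or a carboxylic acid, would also behave differently on the two cores. They also leave open whether the same reversal would appear if a shorter chain replaced the octyl chain.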